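The source may report more compounds than this note shows. Statements on the series, on what has been measured and on what is new or still open speak of the compounds shown alone.

Compound 1 `COC(=O)c1cc(-c2cccc(NC(=O)c3ccc(/C=C/C(=O)c4cccnc4)cc3)c2)on1` has in an ADME assay on Vero cells (Chlorocebus sabaeus) for cytotoxicity, read by MTT assay, with a stated time of 72 h (on this read-out lower numbers stand for higher toxicity in this test and higher numbers for lower toxicity in this test), the entry "not determined" (no result reported). Compound 2 `COC(=O)c1cc(-c2cccc(NC(=O)c3ccc(/C=C/C(=O)c4ccccc4OC)cc3)c2)on1` gives in this assay only the limit > 40 ug/mL. Compound 3 `CCCOc1ccc(C(=O)/C=C/c2ccc(C(=O)Nc3cccc(-c4cc(C(=O)OC)no4)c3)cc2)cc1` likewise gives in this assay only the limit > 40 ug/mL. Compound 3 therefore stands on a limit, as does one other value in the set, while the third entry carries no number at all. Among the compounds with values here, the single change made within the measured pairs, a step that the two limits leave unreadable from compound 2 to compound 3, is a step whose size cannot be read, since both of its ends are limits. Within the data shown here, the one piece of evidence that bears on the set is the limit of > 40 ug/mL in this assay, at which 2 of the 3 values shown sit.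

Compound 4 `COC(=O)c1cc(-c2cccc(NC(=O)c3ccc(/C=C/C(=O)c4cccc(F)c4)cc3)c2)on1` differs from compound 3 by 3-fluorophenyl in place of 4-propoxyphenyl on a carbonyl carbon. Among the measured compounds shown here, no measured step covers a change of this kind with a readable size; the pair from compound 2 to compound 3 also exchanged the group on the carbonyl carbon and left no readable step. On that basis the step that the limit leaves unreadable from compound 3 to compound 4 is expected to stay within the scatter, if it can be read at all, because the limit of > 40 ug/mL in this assay, at which 2 of the 3 values shown sit, holds both measured values. Compound 4 is accordingly estimated at 50 ug/mL in this assay, with a range from 25 ug/mL to 100 ug/mL, and is most likely to be reported again only as a limit.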

Compound 4, half-maximal cytotoxic concentration: > 40 ug/mL
Compound 4 gave a limit, no number; the forecaster's own chance of this, stated with the estimate: 70%; the middle value does not contradict the limit.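

Compound 4 gives in this assay only a limit, > 40 ug/mL. The steps from compound 2 to compound 4 and from compound 3 to compound 4 have limits at both ends and cannot be read. The compounds shown leave open where their half-maximal cytotoxic concentrations actually lie and whether exchanging the group on the carbonyl carbon shifts them.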